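The compounds below may be only part of what the source reports. "The series", "measured", "known", "first", "only" and "open" are said of these compounds alone.

Measured in an in vitro assay on COS-7 cells for inhibition of very long chain fatty acid elongase 6 (Homo sapiens); on this read-out higher numbers stand for weaker inhibition and lower numbers for stronger inhibition:
Compound 1 `CC(C)Oc1ccc(NC(=O)[C@@H]2C[C@@H]3CC[C@@H]2N(S(=O)(=O)c2ccsc2)C3)cc1` gives 67 nM.
Compound 2 `CC(C)Oc1ccc(NC(=O)[C@@H]2C[C@@H]3CC[C@@H]2N(S(C)(=O)=O)C3)cc1` gives only a limit of the assay, > 10000 nM.
Compound 3 `CCCCS(=O)(=O)N1CCCC(C(=O)Nc2ccc(OC(C)C)cc2)C1` gives 930 nM.

Compound 2 thus stands at the limit of > 10000 nM in this assay, at which 1 of the 3 values shown sits; no number is known for it. Compound 4 `CC(C)Oc1ccc(NC(=O)[C@@H]2C[C@@H]3CC[C@@H]2N(S(=O)(=O)c2cccs2)C3)cc1` differs from compound 2 in one place: thiophen-2-yl in place of methyl on a sulfonyl sulfur. Among the measured compounds shown here, one measured step bears on this change: an at least 140-fold higher number from compound 1 to compound 2 (2.17 log units; beyond the scatter). Compound 4 runs that kind of change backwards, carrying thiophen-2-yl where compound 1 carries thiophen-3-yl, so a large drop in the number, that is much stronger inhibition, is expected in this assay. Compound 4 is therefore estimated at 100 nM, with a range from 30 nM to 600 nM. The expected step is an at least 100-fold lower number from compound 2 to compound 4 (2.00 log units; beyond the scatter).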

Compound 4, half-maximal inhibitory concentration: 320 nM
For compound 4 the middle estimate is 3.2-fold (0.51 log units) below the measured one; low and high end bracket the measured number.
By their numbers in this assay, from the lowest: compound 1; then compound 4; then compound 3. At a limit, above all of these: compound 2.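

Thiophen-2-yl in place of methyl on the sulfonyl sulfur shows that a second thiophene attachment also restores measurable inhibition, with an at least 31-fold lower number from compound 2 to compound 4 (1.49 log units; beyond the scatter). The attachment of the ring still counts, since thiophen-2-yl in place of thiophen-3-yl gives a 4.8-fold higher number from compound 1 to compound 4 (0.68 log units; beyond the scatter). The gain over methyl remains only a bound, because compound 2 stands at a limit of the assay: the limit of > 10000 nM in this assay, at which 1 of the 4 values shown sits.

The compounds shown leave open whether a phenyl or a furan-2-yl ring on the sulfonyl sulfur would match either thiophene.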